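Trifluoromethyl for Methyl on the Core of Compound 1

The compounds below may be only part of what the source reports. "The series", "measured", "known", "first", "only" and "open" are said of these compounds alone.

The measured compounds:
Compound 1, `CNc1nc(C)c(C(=O)N/N=C/c2cccc(C(F)(F)F)c2)s1`: > 100 ug/mL
Compound 2, `CN(C(=O)NC(=O)c1cccc(C(F)(F)F)c1)c1nc(C(F)(F)F)c(C(=O)N/N=C/c2ccc(C(F)(F)F)cc2)s1`: 7.71 ug/mL
Compound 3, `CNc1nc(C)c(C(=O)N/N=C/c2cc(C(F)(F)F)cc(C(F)(F)F)c2)s1`: > 100 ug/mL

In a functional assay on HepG2 cells (Homo sapiens) for inhibition, read by MTT assay, with a stated time of 72 h (a lower number here means a stronger inhibitor, a higher number a weaker inhibitor), compound 1 gives > 100 ug/mL, which is a limit of the assay and not a number. Compound 3 likewise gives > 100 ug/mL in this assay, again a limit. The step that the two limits leave unreadable from compound 1 to compound 3 therefore cannot be read; what is known is the limit of > 100 ug/mL in this assay, at which 2 of the 3 values shown sit. Compound 2 differs from compound 1 in several places at once; in this assay compound 2 gives 7.71 ug/mL. Among the measured compounds shown here, no single step links compound 2 to compound 1, so only its value is stated.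

The unmeasured compound 4, `CNc1nc(C(F)(F)F)c(C(=O)N/N=C/c2cccc(C(F)(F)F)c2)s1`, differs from compound 1 by trifluoromethyl in place of methyl on an aromatic carbon. For the measured compounds named here, no measured step covers this change on its own. The two limits for compound 1 and compound 3 give no size to build on, and compound 2 carries the trifluoromethyl on the core together with other changes, so its value cannot be set against compound 1 alone. Compound 4 is therefore expected to stay near the limit of compound 1, with an estimated step of an at least 1.2-fold lower number from compound 1 to compound 4 (0.09 log units; that floor lies within the scatter) and an estimated value of 80 ug/mL in this assay, between 20 ug/mL and 300 ug/mL.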

Compound 4, half-maximal inhibitory concentration: > 100 ug/mL
Compound 4 gave a limit, no number (the forecaster's own chance of this, stated with the estimate: 65%); middle value at least 1.2-fold (0.09 log units) away from the limit.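

Compound 4 gives > 100 ug/mL in this assay, which is a limit and not a number. Among the compounds shown here, compound 1 also sits at a limit, so no step between compound 1 and compound 4 can be read: the limit of > 100 ug/mL in this assay, at which 3 of the 4 values shown sit.

The compounds shown leave open whether trifluoromethyl in place of methyl on an aromatic carbon changes the value at all.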